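The source may hold more compounds than are shown below. What is called first, only, known or untested is meant among the compounds shown, and "the series" means these compounds.

Going by the values given here, compound 2 `Cn1c(COc2cccc(C(=O)O)c2)nc2ccc(Oc3ccc(Cl)cn3)cc21` gives 17 ug/mL in a physicochemical assay for solubility, read by HPLC, measured as thermodynamic solubility, with a stated time of 4 h, at pH 6.8 (a higher number here means a more soluble compound, a lower number a less soluble compound), the highest of the two numbers measured so far. Its only companion, compound 1 `Cc1ccc(Oc2ccc3nc(COc4cccc(C(=O)O)c4)n(C)c3n2)cc1C`, gives 16 ug/mL in this assay, a gap within the usual scatter, so the two compounds cannot be told apart on solubility. Compound 3 `Cc1cc(Cl)cnc1Oc1ccc2nc(COc3cccc(C(=O)O)c3)n(C)c2c1`, not yet measured, differs from compound 2 in one change: methyl in place of hydrogen on an aromatic carbon. Among the compounds with values here, no measured pair shows this kind of change, so nothing here tells its effect. The step of a 1.5-fold lower number from compound 2 to compound 3 (0.19 log units; within the scatter) is expected to be small and downward, within the scatter. Compound 3 is expected to give about 11 ug/mL, within 5 ug/mL to 25 ug/mL.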

Compound 3, solubility: 3.9 ug/mL
For compound 3 the middle estimate is 2.8-fold (0.45 log units) above the measured one; measured number outside the range, below it.
By their numbers in this assay, from the lowest: compound 3; then compounds 1 and 2 (each within the scatter of the next).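

Replacing 5-chloropyridin-2-yl with 5-chloro-3-methylpyridin-2-yl gives a 4.4-fold lower number from compound 2 to compound 3 (0.64 log units; beyond the scatter) in this assay. Going by these compounds alone, this is the first measured reading of this change, and it shows that a single methyl on this aromatic carbon, ortho to a large group and two atoms from the ring nitrogen, can move the number beyond the scatter. No measurement shown gives a reason for the drop.

As far as these compounds go, whether an amine, a methoxy group or a fluoro group at this place would act like methyl stays open. So does whether methyl would have the same effect on another ring.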